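The source may hold more compounds than are shown below. What is called first, only, known or untested is meant among the compounds shown, and "the series" means these compounds.

Compound 3 `Clc1ccc(-c2n[nH]cc2N2CCNCC2)cc1` is one of three measured compounds built on a shared core. In an assay on isolated protein for binding affinity to 5-hydroxytryptamine receptor 1D (Homo sapiens) (on this read-out lower numbers stand for stronger inhibition and higher numbers for weaker inhibition), compound 3 reports a limit rather than a number, > 10000 nM. Compound 2 `COc1ccc(-c2n[nH]cc2N2CCNCC2)cc1` likewise reports only a limit in this assay, > 10000 nM. Compound 1 `Fc1cccc(-c2n[nH]cc2N2CCCNCC2)c1`, which differs from the others in more than one place, gives a measured number in this assay, 2540 nM. Compound 3 thus stands at the limit of > 10000 nM in this assay, at which 2 of the 3 values shown sit, with no measured number placing it. Because compound 2 and compound 3 both sit at the limit of > 10000 nM in this assay, at which 2 of the 3 values shown sit, the step that the two limits leave unreadable from compound 2 to compound 3 cannot be sized.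

Compound 4 `Cc1ccc(-c2n[nH]cc2N2CCNCC2)cc1` differs from compound 3 by methyl in place of chloro on an aromatic carbon. For the measured compounds named here, the only measured step touching this part of the molecule is a step that the two limits leave unreadable from compound 2 to compound 3, and it carries no readable size, so no measured step shows what exchanging one substituent for another does here. Since compound 3 already sits at the limit, compound 4 is expected to stay close to it, with an estimated step that the limit leaves unreadable from compound 3 to compound 4. Compound 4 is therefore estimated at 12000 nM, with a range from 3000 nM to 40000 nM.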

Compound 4, inhibition constant: 325 nM
For compound 4 the middle estimate is 37-fold (1.57 log units) above the measured one; the measured number lies below the stated range.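

For the compounds shown here, the position para to a large group on the six-membered aromatic ring turns out to matter strongly in this assay, which the earlier compounds, sitting at a limit, could not show. Methyl in place of chloro gives an at least 30-fold lower number from compound 3 to compound 4 (1.48 log units; beyond the scatter), and methyl in place of methoxy gives an at least 30-fold lower number from compound 2 to compound 4 (1.48 log units; beyond the scatter), so swapping one small group at this place can move the number far beyond the scatter. Both steps are minimum sizes, and the step between the chloro and methoxy compounds still cannot be read, since both ends of each step rest on a limit of the assay: the limit of > 10000 nM in this assay, at which 2 of the 4 values shown sit.

The compounds shown leave open whether methyl is unusual here or whether ethyl, an amine or a carboxylic acid at the same place would also give a lower number. They also leave open whether methyl would have the same effect on the core of compound 1.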